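The source may hold more compounds than are shown below. What is called first, only, known or untested is meant among the compounds shown, and "the series" means these compounds.

Measured compounds:
Compound 1, `O=C(c1cccc(Cl)c1)N1CCC(NS(=O)(=O)c2cc(S(=O)(=O)c3ccccc3)ccc2C(F)(F)F)CC1`: 870 nM in an assay on U2OS cells for inhibition of secreted frizzled-related protein 1 (Homo sapiens), read by a luciferase reporter, with a stated time of 18 h; a lower number here means that less compound is needed, a higher number that more compound is needed for the effect
Compound 2, `O=C(c1ccc(Cl)cc1)N1CCC(NS(=O)(=O)c2cc(S(=O)(=O)c3ccccc3)ccc2C(F)(F)F)CC1`: 1800 nM in this assay

Among the two measured values, compound 2 stands highest, with compound 1 nearest at a 2.1-fold higher number from compound 1 to compound 2 (0.32 log units; beyond the scatter). Compound 3, `O=C(c1ccccn1)N1CCC(NS(=O)(=O)c2cc(S(=O)(=O)c3ccccc3)ccc2C(F)(F)F)CC1`, is not yet measured; it differs from compound 2 by pyridin-2-yl in place of 4-chlorophenyl on a carbonyl carbon. Among the compounds with values here, the only measured step, a 2.1-fold higher number from compound 1 to compound 2 (0.32 log units; beyond the scatter), concerns a shift of the chlorine on the same aromatic ring and so bears only loosely on an exchange for pyridin-2-yl. Within the data shown here, no measured pair shows a chlorine removed or a ring nitrogen added. Compound 3 is therefore expected to give 2500 nM, within 700 nM to 9000 nM, a step of a 1.4-fold higher number from compound 2 to compound 3 (0.14 log units; within the scatter) that is estimated to stay near the scatter.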

Compound 3, half-maximal effective concentration: 230 nM
Beside the measured number, compound 3's estimate is 11-fold (1.04 log units) above it, outside the stated range (below it).
By their numbers in this assay, from the lowest: compound 3; then compound 1; then compound 2.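

Replacing either chlorophenyl group on the carbonyl carbon with pyridin-2-yl lowers the number in this assay, giving a 7.8-fold lower number from compound 2 to compound 3 (0.89 log units; beyond the scatter) and a 3.8-fold lower number from compound 1 to compound 3 (0.58 log units; beyond the scatter). Compound 3 therefore has the lowest number of the three, showing that this position accepts a ring that carries a nitrogen and no chlorine. No evidence is available that bears on the reason for this result.

On these data alone, it remains open whether the ring nitrogen or the loss of chlorine carries the step, a question that plain phenyl would address. Pyridin-3-yl and pyridin-4-yl would show whether the place of the nitrogen counts.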